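This account rests on a few compounds, and the source may have more. Where it says the series, first, only, none or still open, it means among the compounds named here.

The measured compounds and their values:

Compound 1, `CCOC(=O)c1oc2ccc(NS(=O)(=O)c3ccc(Br)cc3)cc2c1C`, gives > 40000 nM in a functional assay on HCT-116 cells (Homo sapiens) for inhibition, read by MTT assay, with a stated time of 72 h (on this read-out higher numbers stand for weaker inhibition and lower numbers for stronger inhibition), which is a limit of the assay and not a number.
Compound 2, `CCOC(=O)c1oc2ccc(NS(=O)(=O)c3ccc(Cl)cc3)cc2c1C`, gives > 40000 nM in this assay, again a limit and not a number.
Compound 3, `CCOC(=O)c1oc2ccc(N(Cc3ccccc3)S(=O)(=O)c3ccc(Br)cc3)cc2c1C`, gives 8700 nM in this assay.

Within the data shown here, compound 3 therefore holds the only actual number among the three; the other two sit at the limit of > 40000 nM in this assay, at which 2 of the 3 values shown sit. Two steps have been measured. From compound 1 to compound 3, putting benzyl in place of hydrogen on the sulfonamide nitrogen, the step is an at least 4.5-fold lower number from compound 1 to compound 3 (0.66 log units; beyond the scatter). From compound 1 to compound 2, chloro in place of bromo on an aromatic carbon, the step is a step that the two limits leave unreadable from compound 1 to compound 2.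

Compound 4, `CCOC(=O)c1oc2ccc(N(Cc3ccccc3)S(=O)(=O)c3cccc(Br)c3)cc2c1C`, differs from compound 3 in one place: 3-bromophenyl in place of 4-bromophenyl on a sulfonyl sulfur. Neither measured step touches this kind of change. The benzyl step concerns the nitrogen, and the halogen swap keeps the bromine's ring position unchanged and cannot be read at all. Among the measured compounds shown here, with no measured step bearing on it, the expectation is that moving the bromine within its ring gives no step beyond the scatter, so the step from compound 3 to compound 4 is estimated at a 1.0-fold higher number from compound 3 to compound 4 (0.01 log units; within the scatter). Compound 4 is accordingly expected to give about 9000 nM in this assay, within a range from 3000 nM to 30000 nM.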

Compound 4, half-maximal inhibitory concentration: > 40000 nM
Compound 4: only a limit was reported (the forecaster's own chance of this, stated with the estimate: 20%); at least 4.4-fold (0.64 log units) between middle value and limit.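

Among these compounds, until now, the only readable change was on the sulfonamide nitrogen. This result shows that the group on the sulfonyl sulfur matters too, even though no atoms are gained or lost: in this assay, 3-bromophenyl in place of 4-bromophenyl gives an at least 4.5-fold higher number from compound 3 to compound 4 (0.66 log units; beyond the scatter). Compound 4 also keeps the benzyl group of compound 3, so within this pair benzyl on the sulfonamide nitrogen does not by itself give a measurable number. The step is only a minimum, and its true size stays unknown, because the reading for compound 4 is a limit of the assay and not a number: the limit of > 40000 nM in this assay, at which 3 of the 4 values shown sit.

The compounds shown do not tell whether a benzyl compound can tolerate anything else on that aromatic ring, such as chloro, methoxy or an amine in place of the bromine. They also leave open what a longer chain such as phenylethyl on the sulfonamide nitrogen, or a carboxylic acid in place of the ethyl ester, would do to the number.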